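A few compounds are considered here, and "the series" means these few. Any claim that something is new, unique, unknown or untested is made for them only; others in the source may bear on it.

Two compounds share a common core, built from a pyridine-type amide linked through an ether to a thiourea, and differ in two places at once. Compound 1 `O=C(c1cc(Oc2cccc(NC(=S)Nc3ccc(F)c(F)c3)c2)ccn1)N1CCCC1` carries a pyrrolidinyl amide and a difluorophenyl thiourea; in a functional assay on PC-3 cells (Homo sapiens) for cytotoxicity, read by MTT assay, with a stated time of 48 h (a higher number here means a weaker inhibitor, a lower number a stronger inhibitor), compound 1 gives 45600 nM. Compound 2 `CC(C)NC(=O)c1cc(Oc2cccc(NC(=S)Nc3ccc(OC(F)(F)F)cc3)c2)ccn1` carries an isopropyl amide and a trifluoromethoxyphenyl thiourea; in this assay compound 2 gives 11800 nM, the lower of the two numbers, with the gap to compound 1 lying beyond the scatter. The two compounds differ in two places. Their values alone do not say which change matters.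

Compound 3 `O=C(c1cc(Oc2cccc(NC(=S)Nc3ccc(OC(F)(F)F)cc3)c2)ccn1)N1CCCC1` keeps the trifluoromethoxyphenyl thiourea of compound 2 and changes only the amide: pyrrolidin-1-yl in place of isopropylamino on a carbonyl carbon. Going by the values given here, no measured pair shows this change on its own, so the expectation rests on compound 2 11800 nM alone. The step from compound 2 to compound 3 in this assay is expected to be small, a 1.3-fold higher number from compound 2 to compound 3 (0.10 log units; within the scatter), in either direction and not clearly beyond the scatter. Compound 3 is therefore estimated at 15000 nM, within a range of 5000 nM to 45000 nM.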

Compound 3, half-maximal inhibitory concentration: 34100 nM
Beside the measured number, compound 3's estimate is 2.3-fold (0.36 log units) below it, within the range that was stated.
By their numbers in this assay, from the lowest: compound 2; then compounds 3 and 1 (each within the scatter of the next).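

In this assay, with the trifluoromethoxyphenyl thiourea held fixed, pyrrolidin-1-yl in place of isopropylamino on a carbonyl carbon gives a 2.9-fold higher number from compound 2 to compound 3 (0.46 log units; beyond the scatter), so this amide change alone produces a modest step beyond the scatter, which the two-place comparison of compound 1 and compound 2 could not isolate. With the pyrrolidin-1-yl amide held fixed, 4-(trifluoromethoxy)phenyl in place of 3,4-difluorophenyl on an amide-type nitrogen gives a 1.3-fold lower number from compound 1 to compound 3 (0.13 log units; within the scatter), which lies within the scatter, so among these three compounds only the amide step can be told apart from noise. No measurement available here explains why the amide step occurs.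

From the compounds shown here alone, it remains open whether the same amide step would appear with the 3,4-difluorophenyl thiourea, since only the trifluoromethoxyphenyl pair shows it. The change both adds a ring and removes the hydrogen-bond donor counted on isopropylamino, and amides carrying methylamino or dimethylamino on the same carbonyl carbon would help separate those two differences.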